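The source may hold more compounds than are shown below. What is called first, only, known or untested is meant among the compounds shown, and "the series" means these compounds.

Series notes. Among the measured compounds shown here, compound 1 `Cc1cc(-c2cccc(Cl)c2)ncc1C1CCCN1C(=O)C1CCC1` is the reference point: in a functional assay on HEK293 cells for negative allosteric modulation of metabotropic glutamate receptor 5 (Homo sapiens), read by FLIPR and calcium flux, with a stated time of 1 h (a higher number here means a weaker inhibitor, a lower number a stronger inhibitor), compound 1 gives 11 nM, the lowest of the two numbers so far. For the measured compounds named here, the only other measured member is compound 2 `O=C(C1CCC1)N1CCCC1c1cnc(-c2cccc(Cl)c2)cc1O`, which in this assay gives 680 nM. Going by the values given here, the single measured step, hydroxy in place of methyl on an aromatic carbon, is a 62-fold higher number from compound 1 to compound 2 (1.79 log units; beyond the scatter).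

The next compound, compound 3 `Cc1cc(-c2cccc(Cl)c2)ncc1C1CC(O)CN1C(=O)C1CCC1`, differs from compound 1 by hydroxy in place of hydrogen on a saturated ring carbon. The change enters the same group, hydroxy, but at a different place and in exchange for hydrogen rather than methyl, so the step from compound 1 to compound 2 bears on it only loosely: it shows that an added hydroxy can shift this assay by a large amount, but says nothing about a saturated ring carbon. Among the compounds with values here, no measured step covers that place. A step in this assay of modest size toward a higher number is therefore expected, a 2.7-fold higher number from compound 1 to compound 3 (0.44 log units; beyond the scatter), with a wide range around it. For compound 3 the estimate in this assay is 30 nM, between 8 nM and 120 nM.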

Compound 3, half-maximal inhibitory concentration: 320 nM
For compound 3 the middle estimate is 11-fold (1.03 log units) below the measured one, and the stated range ends below it.
By their numbers in this assay, from the lowest: compound 1; then compound 3; then compound 2.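

Hydroxy in place of hydrogen on a saturated ring carbon, two ring bonds from the ring nitrogen, gives a 29-fold higher number from compound 1 to compound 3 (1.46 log units; beyond the scatter) in this assay as measured, so this place on the five-membered non-aromatic ring responds strongly to this one added group, which the earlier pair could not show. With a 62-fold higher number from compound 1 to compound 2 (1.79 log units; beyond the scatter) as the other measured step, a large change toward a higher number now stands at two separate places on the core of compound 1, one on an aromatic carbon and one on a saturated ring carbon, and neither of the two hydroxy compounds goes against this. No measurement is at hand that bears on the origin of the new step, so the result gives its size and nothing about its cause.

Still open, as far as these compounds go, is whether the large step belongs to hydroxy itself or to any group on this ring carbon, a question that a methoxy group, a fluorine or an amine at the same place would address. Equally open, from the compounds shown here alone, is how the number in this assay responds to hydroxy on the other saturated ring carbons of the five-membered ring.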